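A few compounds are considered here, and "the series" means these few. Any claim that something is new, unique, unknown or untested is made for them only; others in the source may bear on it.

Compound 2 `COc1ccc(C(=O)/C=C/c2cc(-c3cc(OC)c(OC)c(OC)c3)n[nH]2)cc1OC` gives 85% in a functional assay on UACC-257 cells (Homo sapiens) for cytotoxicity, read by sulforhodamine B assay, with a stated time of 48 h, tested at 0.01 uM (a lower number here means a stronger effect, a higher number a weaker effect of the compound at the concentration tested), the lower of the two numbers measured to date, compound 1 `COc1cc(-c2cc(/C=C/C(=O)c3ccc(Cl)c(Cl)c3)[nH]n2)cc(OC)c1OC` giving 96% in this assay. Going by the values given here, the only measured step, a number 11 percentage points lower from compound 1 to compound 2 (beyond the scatter), altered the same ring that is altered on the way to compound 3 `COc1ccc(C(=O)/C=C/c2cc(-c3cc(OC)c(OC)c(OC)c3)n[nH]2)cc1`, though by a different change. The change to compound 3 is hydrogen in place of methoxy on an aromatic carbon. Among the compounds with values here, no measured step removes a methoxy. The step expected, a number 3 percentage points higher from compound 2 to compound 3 (within the scatter), is therefore small, near the scatter, in either direction. Compound 3 is expected to give 88%, within 74% to 100%.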

Compound 3, a percentage reported as activity, at one concentration (the size of the read-out at that concentration, not a potency): 97%
Compound 3: middle estimate off by 9 percentage points, on the low side; the measured number falls inside the stated range.
By their numbers in this assay, from the lowest: compound 2; then compounds 1 and 3 (each within the scatter of the next).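

In this assay, the methoxy lost on going to the 4-methoxyphenyl ring matters, with a number 12 percentage points higher from compound 2 to compound 3 (beyond the scatter) as the first read on removing a group from this ring. The 4-methoxyphenyl and 3,4-dichlorophenyl rings cannot be told apart, with a number 1 percentage points higher from compound 1 to compound 3 (within the scatter), so among these compounds only the 3,4-dimethoxyphenyl ring stands apart. No evidence on the cause of this step is at hand. Open, going by these compounds, is whether a hydroxyl or an amine at this carbon would keep the number of compound 2. A single concentration also shows only a stronger or weaker effect at that concentration.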